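A few compounds are considered here, and "the series" means these few. Any claim that something is new, unique, unknown or untested is made for them only; others in the source may bear on it.

Working notes on the series

Compound 1, `COc1ccc(/C=C/S(=O)(=O)Cc2ccc(OC)cc2)cc1`, is the reference point. In a functional assay on DLD-1 cells (Homo sapiens) for antiproliferative activity, read by trypan blue exclusion (on this read-out lower numbers stand for stronger inhibition and higher numbers for weaker inhibition), compound 1 returns only a limit, > 20000 nM. Compound 3, `COc1ccc(CS(=O)(=O)/C=C/c2ccc(OC)c(OC)c2)cc1`, carries the change methoxy in place of hydrogen on an aromatic carbon relative to compound 1. In this assay compound 3 also returns a limit, > 20000 nM. The step that the two limits leave unreadable from compound 1 to compound 3 is therefore not readable as a size, which follows from the limit of > 20000 nM in this assay, at which 2 of the 3 values shown sit.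

Compound 2, `COc1ccc(CS(=O)(=O)/C=C/c2ccccc2OC)cc1`, has the same atoms as compound 1 joined differently; the difference between the two cores is not broken down here. In this assay, among the compounds with values here, compound 2 gives 7500 nM, the only number among the three measured compounds.

Compound 4, `COc1ccc(CS(=O)(=O)/C=C/c2cc(OC)ccc2OC)cc1`, is not yet measured. Relative to compound 2 it carries methoxy in place of hydrogen on an aromatic carbon. This is the same kind of change as that from compound 1 to compound 3, but not the same: in compound 3 the entering methoxy sits ortho to a methoxy group and meta to a large group, whereas in compound 4 it sits meta to a large group and para to a methoxy group.

Within the data shown here, the expected step of a 1.3-fold higher number from compound 2 to compound 4 (0.12 log units; within the scatter) from compound 2 to compound 4 is kept small, since the only analogous step, a step that the two limits leave unreadable from compound 1 to compound 3, gives no readable size and compound 2 at 7500 nM is the sole anchor. Compound 4 is accordingly estimated at 10000 nM in this assay, within 3000 nM and 20000 nM, with a real chance that only a limit is reported.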

Compound 4, half-maximal inhibitory concentration: > 20000 nM
Compound 4: a limit, no number; the forecaster's own chance of this, stated with the estimate: 40%; middle value at least 2.0-fold (0.30 log units) away from the limit.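

On the core of compound 2, methoxy in place of hydrogen on an aromatic carbon, meta to a large group and para to a methoxy group, gives an at least 2.6-fold higher number from compound 2 to compound 4 (0.42 log units; beyond the scatter), so on this core and at this place the change moves the read-out toward weaker inhibition. In this assay compound 4 returns only a limit, > 20000 nM, and the step therefore has a lower bound and no upper end, leaving its full size unknown: the limit of > 20000 nM in this assay, at which 3 of the 4 values shown sit. The steps cannot be compared across cores, since the step between compound 1 and compound 3 cannot be read and that methoxy enters at a different place, so a single readable step shows the outcome on one core only and gives no rule that carries from one core to another.

The compounds shown leave open whether the loss on the core of compound 2 belongs to methoxy itself or to any group entering at that place, which an amine, a carboxylic acid or a longer chain such as butoxy at the same carbon would help to separate. They also leave open whether any group added to compound 2 would give a stronger read-out than compound 2 itself.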